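Swapping a pyridine for an isopropylphenyl on the amide

The source may hold more compounds than are shown below. What is called first, only, known or untested is meant among the compounds shown, and "the series" means these compounds.

Measured compounds:
Compound 1, `Cc1cccc(Cn2c(CN3CCN(C(=O)c4cccnc4)CC3)nc3ccccc32)c1`, 24.5%
Compound 2, `CC(C)CCn1c(CN2CCN(C(=O)c3ccco3)CC2)nc2ccccc21`, 42.1%
Compound 3, `CC(C)CCn1c(OC2CCN(C(=O)c3ccco3)CC2)nc2ccccc21`, 30.8%

All three were tested in an assay on isolated protein for inhibition of aldehyde dehydrogenase 1A1 (Homo sapiens), read by spectrophotometry, tested at 10 uM; a higher number here means more inhibition at the concentration tested (going by the name of the read-out), a lower number less inhibition. Compound 1 gives the lowest of the three numbers in this assay, at 24.5%. Its nearest neighbour is compound 3, whose value in this assay of 30.8% lies within the scatter of that of compound 1, so the two cannot be told apart. Compound 2, at 42.1% in this assay, stands beyond the scatter above compound 1.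

The unmeasured compound 4, `Cc1cccc(Cn2c(CN3CCN(C(=O)c4ccc(C(C)C)cc4)CC3)nc3ccccc32)c1`, keeps the core of compound 1 and changes only the group on the carbonyl carbon: 4-isopropylphenyl in place of pyridin-3-yl on a carbonyl carbon. For the measured compounds named here, no pair among the measured compounds shows a change of this kind, so the direction of the step is open. The expectation is a step from compound 1 to compound 4 of about a number 9.5 percentage points higher from compound 1 to compound 4 (within the scatter) in this assay, a modest rise that may well stay inside the scatter. Compound 4 is therefore estimated at 34% in this assay, between 15% and 55%.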

Compound 4, a percentage reported as inhibition, at one concentration (the size of the read-out at that concentration, not a potency): 67.6%
For compound 4 the middle estimate is 33.6 percentage points below the measured one; measured number above the stated range.
By their numbers in this assay, from the lowest: compounds 1 and 3 (each within the scatter of the next); then compound 2; then compound 4.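

In this assay, for the compounds shown here, the group on the carbonyl carbon clearly matters: with the rest of the molecule unchanged, 4-isopropylphenyl in place of pyridin-3-yl gives a number 43.1 percentage points higher from compound 1 to compound 4 (beyond the scatter) and is the first single-place change in this set. The group that enters is made of carbon only and has no hydrogen-bond acceptor, while the group that leaves has a ring nitrogen and one acceptor, so this one step changes both the ring and what it carries. No measurement at hand explains the rise.

The pair cannot separate the loss of the ring nitrogen from the gain of the isopropyl group, a question that a plain phenyl on the carbonyl carbon could help to settle. Going by these compounds, whether 4-methylphenyl or 4-tert-butylphenyl would do as well, and whether the same swap would raise the number for compound 2, also stays open.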